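Swapping One Aromatic Ring for Another on Compound 3

A few compounds are considered here, and "the series" means these few. Any claim that something is new, unique, unknown or untested is made for them only; others in the source may bear on it.

Compounds 1, 2 and 3 share one core and differ only in the group on an amine nitrogen in a ring. Compound 1 `CC(C)N1CCN(Cc2csc(N)c2C(=O)c2ccc(Cl)cc2)CC1` gives -7.4% in a functional assay on CHO cells with adenosine receptor A1 (Homo sapiens) as the target, read by cAMP accumulation and immunoassay, with a stated time of 6 min, tested at 10 uM; a higher number here means a weaker effect of the compound at the concentration tested, a lower number a stronger effect. Compound 2 `Nc1scc(CN2CCN(c3ccncc3)CC2)c1C(=O)c1ccc(Cl)cc1` gives -15% in this assay, and compound 3 `Nc1scc(CN2CCN(c3ccccc3F)CC2)c1C(=O)c1ccc(Cl)cc1` gives -15% in this assay. The steps of a number 7.6 percentage points lower from compound 1 to compound 2 (within the scatter) and a number 7.6 percentage points lower from compound 1 to compound 3 (within the scatter) both stay within the scatter, as does no change at the digits printed from compound 2 to compound 3 (within the scatter). Compound 3 thus stands level with compound 2, the two together showing the lowest of the three numbers, with compound 1 within the scatter of both.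

Compound 4 `Nc1scc(CN2CCN(c3ccc(Cl)c(Cl)c3)CC2)c1C(=O)c1ccc(Cl)cc1` arises from compound 3 by 3,4-dichlorophenyl in place of 2-fluorophenyl on an amine nitrogen in a ring. Because no change at the digits printed from compound 2 to compound 3 (within the scatter) also exchanged one six-membered aromatic ring for another on the same ring nitrogen, it bears most directly on this change, and it showed nothing beyond the scatter. Compound 4 is therefore expected to give -13%, within -28% to 2%. The expected step of a number 2 percentage points higher from compound 3 to compound 4 (within the scatter) stays within the scatter.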

Compound 4, a percentage reported as activity, at one concentration (the size of the read-out at that concentration, not a potency): -62%
The estimate for compound 4 lay 49 percentage points above the measured number; the measured number lies below the stated range.
By their numbers in this assay, from the lowest: compound 4; then compounds 2, 3 and 1 (each within the scatter of the next).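

Within the data shown here, on the ring nitrogen of the piperazine-like ring, the earlier compounds suggested that the choice of aromatic group made little difference, but 3,4-dichlorophenyl gives a clearly stronger effect at the concentration tested in this assay: a number 47 percentage points lower from compound 3 to compound 4 (beyond the scatter) and a number 47 percentage points lower from compound 2 to compound 4 (beyond the scatter). The step away from the non-aromatic isopropyl group is similar in scale, a number 54.6 percentage points lower from compound 1 to compound 4 (beyond the scatter), so compound 4 stands apart from all three earlier compounds, and the two aromatic groups in compounds 2 and 3 do not share its effect. No measurement available here explains this difference.

The change from compound 3 to compound 4 removes a fluorine and adds two chlorines, so the contribution of each chlorine cannot be separated. A plain phenyl ring, or a phenyl ring carrying a single chlorine, would be the group to compare on this nitrogen.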